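The source may hold more compounds than are shown below. What is called first, only, known or untested is meant among the compounds shown, and "the series" means these compounds.

Measured compounds in this assay:
compound 1 `N#CN/C(=N\CCNC(=O)c1ccc(N)c(I)c1)NCCCOc1cccc(CN2CCCCC2)c1` — 27.5 nM
compound 2 `N#CN/C(=N\CCNC(=O)c1cc(I)c(N)c(I)c1)NCCCOc1cccc(CN2CCCCC2)c1` — 16.2 nM

In a functional assay on cardiac atrium for antagonist activity at histamine H2 receptor (Cavia porcellus), tested at 1 uM (on this read-out lower numbers stand for tighter binding and higher numbers for weaker binding), compound 2 gives the lower of the two numbers, but the gap between them is a 1.7-fold lower number from compound 1 to compound 2 (0.23 log units; within the scatter), so the two compounds cannot be ranked. That single step, iodo in place of hydrogen on an aromatic carbon, is the only one measured so far.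

Compound 3 `N#CN/C(=N\CCNC(=O)c1ccc(N=[N+]=[N-])c(I)c1)NCCCOc1cccc(CN2CCCCC2)c1` differs from compound 2 by 4-azido-3-iodophenyl in place of 4-amino-3,5-diiodophenyl on a carbonyl carbon. Part of this change reverses the measured step: one iodine is taken away again, and the step from compound 1 to compound 2 was a 1.7-fold lower number from compound 1 to compound 2 (0.23 log units; within the scatter), so this part should count for little. Among the measured compounds shown here, the other part, azido in place of amino, has no measured counterpart, and no direction can be drawn for it from the data.

The step from compound 2 to compound 3 is therefore expected to be a 1.9-fold higher number from compound 2 to compound 3 (0.27 log units; within the scatter). Compound 3 is estimated at 30 nM, with a range from 10 nM to 90 nM.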

Compound 3, dissociation constant: 155 nM
Estimate against measurement, compound 3: 5.2-fold (0.71 log units) below, and the stated range ends below it.
By their numbers in this assay, from the lowest: compounds 2 and 1 (each within the scatter of the next); then compound 3.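

In this assay, azido in place of amino on an aromatic carbon moves the number beyond the scatter, with a 5.6-fold higher number from compound 1 to compound 3 (0.75 log units; beyond the scatter), so this position responds to a change of group in a way the iodo step did not show. The replacement of 4-amino-3,5-diiodophenyl by 4-azido-3-iodophenyl on a carbonyl carbon also lies beyond the scatter, with a 9.6-fold higher number from compound 2 to compound 3 (0.98 log units; beyond the scatter), while a 1.7-fold lower number from compound 1 to compound 2 (0.23 log units; within the scatter); both routes to compound 3 therefore include the same exchange of amino for azido. No available evidence bears on the reason for this shift.

Still open, going by these compounds, is whether a hydroxyl or methoxy group on that aromatic carbon would give a number closer to compound 1 or to compound 3. Also open, on these data alone, is whether a second iodine on the azido compound, giving 4-azido-3,5-diiodophenyl, would stay within the scatter of compound 3.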